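Methyl in place of hydrogen: compound 2 to compound 3

A few compounds are considered here, and "the series" means these few. Any claim that something is new, unique, unknown or untested is made for them only; others in the source may bear on it.

Two compounds of the series have been run in a functional assay on T-24 cells (Homo sapiens) for cytotoxicity, read by CCK-8 assay, with a stated time of 24 h; a lower number here means a stronger inhibitor, a higher number a weaker inhibitor. Compound 1 `C=C1CCC(c2csc(/C=C(\C)C(N)=O)c2)CC1` reaches only the limit of > 50000 nM in this assay, so no number is known for it. Compound 2 `C/C(=C\c1cc(-c2ccccc2)co1)C(N)=O` likewise stops at the limit of > 50000 nM in this assay. On the numbers shown, compound 2 thus stands at the limit itself and nowhere else: the limit of > 50000 nM in this assay, at which 2 of the 2 values shown sit. Compound 3 `C/C(=C\c1cc(-c2ccc(C)cc2)co1)C(N)=O` differs from compound 2 by methyl in place of hydrogen on an aromatic carbon. Going by the values given here, no step between measured compounds is available, so the size of the change in this assay cannot be read from the series; a step beyond the scatter is not expected in either direction. The expected step is a step that the limit leaves unreadable from compound 2 to compound 3. Compound 3 is therefore expected to give about 60000 nM in this assay, with a range from 20000 nM to 200000 nM, most likely again only a limit.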

Compound 3, half-maximal inhibitory concentration: > 50000 nM
Compound 3 ended at the assay's limit (the forecaster's own chance of this, stated with the estimate: 80%); the middle value is on the limit's open side.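

The step from compound 2 to compound 3 cannot be read in this assay because both compounds end at a limit and not at a number: the limit of > 50000 nM in this assay, at which 3 of the 3 values shown sit.

Compounds 1, 2 and 3 leave open whether any change to this series gives a measurable value in this assay at all.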